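The source may hold more compounds than are shown below. What is called first, only, known or untested is meant among the compounds shown, and "the series" means these compounds.

Measured so far in a physicochemical assay for permeability, using PAMPA (on this read-out higher numbers stand for higher permeability and lower numbers for lower permeability), for this series:
- compound 1 `C[C@@H](Oc1cc2oc(=O)n(CCC(=O)O)c2cc1Cl)c1ccc(F)cn1` gives 31 nm/s as its read-out
- compound 2 `O=C(O)CCn1c(=O)oc2cc(OCc3ccccc3)c(Cl)cc21` is recorded as "not determined" (no result reported)

Compound 2 has no standing on these numbers, as no value was determined for it in this assay and it offers no baseline. The next compound is compound 3 `C[C@@H](Oc1cc2oc(=O)n(CCC(=O)O)c2cc1Cl)c1cccnn1`, not yet measured. The structural change is a group of 8 heavy atoms (6 carbon, 2 nitrogen; one six-membered aromatic ring with 2 hetero atoms) in place of a group of 7 heavy atoms (7 carbon; one six-membered aromatic ring of carbon only), on an oxygen on an aromatic ring, so a group of 8 heavy atoms with one six-membered aromatic ring with 2 hetero atoms replaces a group of 7 heavy atoms, on an oxygen on an aromatic ring. Among the measured compounds shown here, no measured step exists to scale this change. For the measured compounds named here, the only number available is that of compound 1 at 31 nm/s, and the expectation is anchored there. A moderate downward step from that level, somewhat beyond the scatter, is expected, though with low confidence. For compound 3 the estimated permeability is 12 nm/s, with an expected range of 4 nm/s to 35 nm/s.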

Compound 3, apparent permeability: < 3 nm/s
Compound 3 gave a limit, no number (the forecaster's own chance of this, stated with the estimate: 25%); middle value at least 4.0-fold (0.60 log units) away from the limit.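

In this assay compound 3 stands at < 3 nm/s, which is a limit of the assay and not a number. Among the compounds shown here, on the saturated chain carbon bound to an oxygen on an aromatic ring, pyridazin-3-yl in place of 5-fluoropyridin-2-yl gives an at least 10-fold lower number from compound 1 to compound 3 (1.01 log units; beyond the scatter), the first measured change, showing that the read-out responds strongly to the ring at this place. The full size of the step stays unresolved, as only a bound is available: the limit of < 3 nm/s in this assay, at which 1 of the 3 values shown sits.

On these data alone, what a plain pyridin-2-yl or phenyl ring would give on that carbon remains open, and with it whether the fluorine or the ring nitrogens carry the step. The benzyl group of compound 2 offers no comparison, as no result is reported for it.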